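Swapping Benzyl for Pyridin-2-ylmethyl: Compound 3 to Compound 4

A few compounds are considered here, and "the series" means these few. Any claim that something is new, unique, unknown or untested is made for them only; others in the source may bear on it.

Compound 3 `O=C(NO)c1ccc(CN(Cc2ccccc2)S(=O)(=O)c2cc(F)c(F)c(F)c2F)cc1` gives 115 nM in an assay on isolated protein for inhibition of histone deacetylase 11 (Homo sapiens), read by mobility shift assay (a higher number here means a weaker inhibitor, a lower number a stronger inhibitor), the lowest of the two numbers shown, though compound 1 `O=C(NO)c1ccc(CN(Cc2ccccc2)S(=O)(=O)c2c(F)c(F)c(F)c(F)c2F)cc1` stands within the scatter of it at 122 nM, and the step of a 1.1-fold lower number from compound 1 to compound 3 (0.03 log units; within the scatter) is within the scatter. Compound 2 `CN(C)c1ccc(CN(Cc2ccc(C(=O)NO)cc2)S(=O)(=O)c2c(F)c(F)c(F)c(F)c2F)cc1` shows only a limit in this assay, > 1000 nM. The step of an at least 8.1-fold higher number from compound 1 to compound 2 (0.91 log units; beyond the scatter) lies beyond the scatter, the value being (the limit of > 1000 nM in this assay, at which 1 of the 3 values shown sits). Compound 4 `O=C(NO)c1ccc(CN(Cc2ccccn2)S(=O)(=O)c2cc(F)c(F)c(F)c2F)cc1` differs from compound 3 by pyridin-2-yl in place of phenyl on a saturated chain carbon bound to a sulfonamide nitrogen. Neither measured step touches this benzyl group: one alters a different ring, the other the sulfonyl ring. On that basis compound 4 is expected to give about 150 nM in this assay, between 60 nM and 400 nM, with the step of a 1.3-fold higher number from compound 3 to compound 4 (0.12 log units; within the scatter) expected to stay within the scatter.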

Compound 4, half-maximal inhibitory concentration: 941 nM
For compound 4 the middle estimate is 6.3-fold (0.80 log units) below the measured one, and the stated range ends below it.
By their numbers in this assay, from the lowest: compounds 3 and 1 (each within the scatter of the next); then compound 4. At a limit, above all of these: compound 2.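

Pyridin-2-yl in place of phenyl on a saturated chain carbon bound to a sulfonamide nitrogen gives an 8.2-fold higher number from compound 3 to compound 4 (0.91 log units; beyond the scatter) in this assay. This group is therefore sensitive to a single ring nitrogen with the heavy-atom count unchanged, whereas the change in the sulfonyl ring, a 1.1-fold lower number from compound 1 to compound 3 (0.03 log units; within the scatter), stayed within the scatter. No measurement shown accounts for the step.

As far as these compounds go, it remains open what pyridin-3-yl or pyridin-4-yl would give at this place, and whether any ring nitrogen has this effect. From the compounds shown here alone, it is also open whether the same change would give a similar step on the core of compound 1.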